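A Hexyl Chain Takes the Place of Fluorine

The source may hold more compounds than are shown below. What is called first, only, known or untested is meant among the compounds shown, and "the series" means these compounds.

Three compounds sharing one core were tested in a functional assay on MCF7 cells (Homo sapiens) for antiproliferative activity, with a stated time of 5 days; a higher number here means a weaker inhibitor, a lower number a stronger inhibitor. Compound 1 `COc1ccc(-c2[nH]c3cc(F)ccc3c2C=O)cc1` gives 43 nM and compound 3 `COc1ccc(-c2[nH]c3cc(Cl)ccc3c2C=O)cc1` gives 65 nM, the two linked by a 1.5-fold higher number from compound 1 to compound 3 (0.18 log units; within the scatter). Compound 2 `COc1ccc(-c2[nH]c3ccc(F)cc3c2C=O)cc1` gives 240 nM, the highest of the three numbers, standing beyond the scatter from both, nearer to compound 3 than to compound 1. Compound 4 `CCCCCCc1ccc2[nH]c(-c3ccc(OC)cc3)c(C=O)c2c1` arises from compound 2 by hexyl in place of fluoro on an aromatic carbon. Going by the values given here, no measured step involves a hexyl chain, and the only measured step concerns a halogen exchange at a different place on the core, so the data give little guidance here. Compound 4 is therefore estimated at 200 nM in this assay, within a wide range from 40 nM to 1000 nM. The step so expected, a 1.2-fold lower number from compound 2 to compound 4 (0.08 log units; within the scatter), amounts to none beyond the scatter.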

Compound 4, half-maximal inhibitory concentration: 6 nM
Compound 4: the middle estimate sits 33-fold (1.52 log units) above what was measured, and the stated range ends above it.
By their numbers in this assay, from the lowest: compound 4; then compounds 1 and 3 (each within the scatter of the next); then compound 2.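

Hexyl in place of fluoro at this position of the shared core brings a 40-fold lower number from compound 2 to compound 4 (1.60 log units; beyond the scatter) in this assay, whereas the only earlier step, a halogen exchange at a different place, stayed within the scatter. The position therefore accepts a chain as long as hexyl, and this change lowers the number sharply. No measurement shown here accounts for the size of this step. From the compounds shown here alone, it remains open whether a shorter butyl chain, a longer octyl chain or a hexyl chain ending in an amine would give a similar number, and whether hexyl at the place of the halogen in compound 1 would do the same.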